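The source may report more compounds than this note shows. Statements on the series, on what has been measured and on what is new or still open speak of the compounds shown alone.

Compound 1 `CC1CCN(c2nc(C(F)(F)F)ccc2CNC(=O)C(c2ccc(NS(C)(=O)=O)c(F)c2)C2CCCCC2)CC1`: 31.1 nM
Compound 2 `Cc1cccc(C(C(=O)NCc2ccc(C(F)(F)F)nc2N2CCC(C)CC2)c2ccc(NS(C)(=O)=O)c(F)c2)c1`: 0.1 nM

Among the compounds with values here, in an assay on CHO cells for antagonist activity at transient receptor potential cation channel subfamily V member 1 (Homo sapiens), read by FLIPR (a lower number here means a stronger inhibitor, a higher number a weaker inhibitor), compound 2 holds the lowest number of the two measured, with compound 1 the only neighbour, a step of a 310-fold lower number from compound 1 to compound 2 (2.49 log units; beyond the scatter) away. Compound 3 `CC1CCN(c2nc(C(F)(F)F)ccc2CNC(=O)C(Cc2ccc(F)cc2)c2ccc(NS(C)(=O)=O)c(F)c2)CC1` is not yet measured. It differs from compound 2 by 4-fluorobenzyl in place of 3-methylphenyl on a saturated chain carbon bound to an aromatic carbon and a carbonyl carbon. Within the data shown here, the one measured step that bears on this position, a 310-fold lower number from compound 1 to compound 2 (2.49 log units; beyond the scatter), shows that the group on that carbon can move this assay by a large amount. A rise in the number is expected for compound 3, though smaller than that step, so its estimate is 3 nM (range 0.3 nM to 30 nM), a step of a 30-fold higher number from compound 2 to compound 3 (1.48 log units; beyond the scatter).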

Compound 3, inhibition constant: 49.3 nM
Compound 3: the middle estimate sits 16-fold (1.22 log units) below what was measured; measured number above the stated range.
By their numbers in this assay, from the lowest: compound 2; then compounds 1 and 3 (each within the scatter of the next).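

In this assay the low number of compound 2 does not carry over to every group with an aromatic ring on this carbon: 4-fluorobenzyl gives a 490-fold higher number from compound 2 to compound 3 (2.69 log units; beyond the scatter) and so loses the whole gain. Against cyclohexyl, the same group gives a 1.6-fold higher number from compound 1 to compound 3 (0.20 log units; within the scatter) and so cannot be told apart from it here, which means a six-membered aromatic ring of carbon only is not enough in itself. Nothing available accounts for this difference.

Going by these compounds, what remains open is whether the gain rests on the methyl or on the ring itself. Plain phenyl, 4-fluorophenyl and unsubstituted benzyl on this carbon would begin to separate these.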